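The compounds below may be only part of what the source reports. "The series", "measured", "known", "first", "only" and "open" are said of these compounds alone.

Compound 2 `CCOC(=O)CCCCCOc1cccc(CN(C(=O)c2ccc(-c3ccc4c(c3)OCCO4)cc2)C(C)C)c1` is one of two compounds tested for cytotoxicity in an ADME assay on BJ cells (Homo sapiens) for cytotoxicity, read by CellTiter-Glo and resazurin assay, with a stated time of 72 h; a higher number here means that more compound is needed for the effect, a lower number that less compound is needed. In that assay compound 2 gives > 24400 nM, which is a limit of the assay and not a number. Compound 1 `CCOC(=O)CCCCCOc1cccc(CN(C(=O)c2ccc(-c3cccc(-c4nnc(C)o4)c3)cc2)C(C)C)c1` gives > 26000 nM in this assay, also a limit. The step that the two limits leave unreadable from compound 1 to compound 2 therefore stays unreadable, as the limit of > 24400 nM in this assay, at which 1 of the 2 values shown sits, and the limit of > 26000 nM in this assay, at which 1 of the 2 values shown sits, show. Compound 3 `CCOC(=O)CCCCCOc1cccc(CN(C(=O)c2ccc(-c3ccc(Cl)c(Cl)c3)cc2)C(C)C)c1` differs from compound 2 by 3,4-dichlorophenyl in place of 2,3-dihydro-1,4-benzodioxin-6-yl on an aromatic carbon. Within the data shown here, no measured step bears on this change, and since both known values sit at limits, compound 3 is expected to give 25000 nM in this assay, within 8000 nM to 60000 nM. The expected step that the limit leaves unreadable from compound 2 to compound 3 is thus no larger than the scatter.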

Compound 3, half-maximal effective concentration: > 26000 nM
Compound 3: a limit, no number (the forecaster's own chance of this, stated with the estimate: 70%); middle value at least 1.0-fold (0.01 log units) from the limit.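

Compound 3 gives a limit and not a number in this assay, as do compound 1 and compound 2, so no step among the three can be read: the limit of > 26000 nM in this assay, at which 2 of the 3 values shown sit.

The compounds shown leave open whether these three differ at all in this read-out, and what concentration each would need for the effect.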